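Replacing the Phenyl of Compound 1

The source may report more compounds than this note shows. Statements on the series, on what has been measured and on what is new or still open speak of the compounds shown alone.

In an ADME assay on BHK cells (Mesocricetus auratus) for cytotoxicity, read by MTT assay, with a stated time of 96 h (a lower number here means that less compound is tolerated, a higher number that more compound is tolerated), compound 1 (`O=C(NC(=S)Nc1cccc(C(F)(F)F)c1)c1ccccc1`) gives > 100000 nM as a reading that is a limit of the assay and not a number. This places compound 1 at the limit of > 100000 nM in this assay, at which 1 of the 3 values shown sits, and gives it no exact position on the scale.

Two relatives have exact readings: compound 2 (`O=[N+]([O-])c1ccc(NC(=S)Nc2cccc(C(F)(F)F)c2)cc1`) gives 9500 nM in this assay and compound 3 (`CCCC[C@H]1CC[C@H](c2ccc(NC(=S)Nc3cccc(C(F)(F)F)c3)cc2)CC1`) also gives 9500 nM in the same test.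

Compound 4 (`O=C(NC(=S)Nc1cccc(C(F)(F)F)c1)[C@H]1C[C@@H]2CC[C@H]1C2`) has yet to be measured. The structural change from compound 1 is a group of 7 heavy atoms (7 carbon; 2 five-membered non-aromatic rings of carbon only) in place of a group of 6 heavy atoms (6 carbon; one six-membered aromatic ring of carbon only), on a carbonyl carbon and so the phenyl leaves the carbonyl carbon, whose other neighbour is an amide-type nitrogen.

Among the measured compounds shown here, only one measured step offers guidance. Placing 4-butylcyclohexyl where nitro stood on an aromatic carbon gave no change at the digits printed from compound 2 to compound 3 (within the scatter) in this assay even though the swap was large. That change lies at a different place, so it is indirect evidence, but it gives no reason to expect a large shift here.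

The expected result is a small step, perhaps toward lower tolerated concentrations. The estimated step is an at least 1.4-fold lower number from compound 1 to compound 4 (0.15 log units; that floor lies within the scatter) and it remains rough, as compound 1 has no exact number. For compound 4 the estimate is 70000 nM with an expected range from 20000 nM to 100000 nM in this assay and a reading at the limit is quite possible.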

Compound 4, half-maximal cytotoxic concentration: 9600 nM
Beside the measured number, compound 4's estimate is 7.3-fold (0.86 log units) above it; the whole stated range lies above it.
By their numbers in this assay, from the lowest: compounds 2, 3 and 4 (each within the scatter of the next). At a limit, above all of these: compound 1.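

The position on the carbonyl carbon turns out to be sensitive in this assay: placing the group with 2 five-membered non-aromatic rings of carbon only where phenyl stood gives an at least 10-fold lower number from compound 1 to compound 4 (1.01 log units; beyond the scatter). Among the compounds shown here, the only earlier step, no change at the digits printed from compound 2 to compound 3 (within the scatter), lay at a different place, on an aromatic carbon, so it could say nothing directly about this position, and a large swap there did not predict what a similar-sized swap would do here. The reading for compound 1 is a limit of the assay and not a number, so this step is a floor and its true size stays unknown: the limit of > 100000 nM in this assay, at which 1 of the 4 values shown sits.

The compounds shown do not separate the loss of the aromatic ring from the other differences in the entering group, such as its 3 defined stereocentres, and the data shown give no cause for the step. From the compounds shown here alone, what a pyridine ring, a plain propyl chain or another spatial arrangement of the same ring system would give on this carbonyl carbon remains open, as does whether an amine on the original phenyl would shift the reading at all.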